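This account rests on a few compounds, and the source may have more. Where it says the series, first, only, none or still open, it means among the compounds named here.

Measured so far in a functional assay on MDA-MB-231 cells (Homo sapiens) for inhibition, read by MTT assay, with a stated time of 72 h; on this read-out higher numbers stand for weaker inhibition and lower numbers for stronger inhibition:

- compound 1, `O=C(CSc1nc(Nc2ccccc2)c2ccccc2n1)Nc1ccc(Cl)c(Cl)c1`: 14500 nM
- compound 2, `O=C(CSc1nc(Nc2ccccc2)c2ccccc2n1)Nc1ccc(F)c(Cl)c1`: 21600 nM
- compound 3, `C=CC(=O)Nc1cccc(NC(=O)CSc2nc(Nc3ccccc3F)c3ccccc3n2)c1`: 18700 nM

Compound 3 and compound 2 carry different cores; the difference between the two cores is not broken down here. Their values, together with that of compound 1, all sit within the scatter of one another.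

One matched pair is measured: chloro in place of fluoro on an aromatic carbon; the step is a 1.5-fold lower number from compound 2 to compound 1 (0.17 log units; within the scatter).

Compound 4, `C=CC(=O)Nc1cccc(NC(=O)CSc2nc(Nc3ccccc3Cl)c3ccccc3n2)c1`, is not yet measured. It differs from compound 3 by chloro in place of fluoro on an aromatic carbon, a change of the same kind as that from compound 2 to compound 1, though here the place is ortho to a large group, whereas in the measured pair it was ortho to a chloro group and para to a large group.

Beside the measured step, the change is expected to give a 1.3-fold lower number from compound 3 to compound 4 (0.13 log units; within the scatter), because the measured pair shows a 1.5-fold lower number from compound 2 to compound 1 (0.17 log units; within the scatter) and compound 3 gives 18700 nM.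

Compound 4 is estimated at 14000 nM.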

Compound 4, half-maximal inhibitory concentration: 12700 nM
Estimate against measurement, compound 4: 1.1-fold (0.04 log units) above; the range from low to high includes it.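

In this assay, chloro in place of fluoro on an aromatic carbon gives a 1.5-fold lower number from compound 3 to compound 4 (0.17 log units; within the scatter). Set beside the earlier step, the change reads the same on both cores: the same change on two cores in this assay, a 1.5-fold lower number (0.17 log units; within the scatter) from compound 2 to compound 1 and a 1.5-fold lower number (0.17 log units; within the scatter) from compound 3 to compound 4, 1.0-fold (0.01 log units) apart, within the scatter of two such steps. This shows agreement between two cores only, and since each step lies within the scatter, it does not establish that chloro and fluoro differ in this assay on either core, nor that the agreement would hold at other places or on other cores.

The compounds shown leave open what bromo, methoxy or an amine on the same aromatic carbon would give. Also open, from the compounds shown here alone, is whether any such group would produce a step beyond the scatter in this assay.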